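The compounds below may be only part of what the source reports. "The series", "measured", "known", "first", "only" and "open" are said of these compounds alone.

Measured compounds in an ADME assay on microsomes from liver (Homo sapiens) for metabolic stability, tested at 2.5 uM; on this read-out lower numbers stand for slow clearance and higher numbers for fast clearance:
Compound 1 `O=S(=O)(c1ccc(F)c(Cl)c1)c1cnc2c(F)cccc2c1-c1cccc(Cl)c1` gives 0.18 mL/min.
Compound 2 `O=S(=O)(c1ccc(F)c(Cl)c1)c1cnc2c(F)cccc2c1-c1ccccc1F` gives 1.39 mL/min.
Compound 3 `O=S(=O)(c1cc(Cl)cc(Cl)c1)c1cnc2c(F)cccc2c1-c1ccc(F)cc1` gives 1.01 mL/min.

Compound 3 sits second highest of the three, near compound 2 (within the scatter) and well apart from compound 1 (beyond the scatter). Compound 4 `O=S(=O)(c1ccc(F)c(Cl)c1)c1cnc2c(F)cccc2c1-c1ccc(F)cc1` differs from compound 3 by 3-chloro-4-fluorophenyl in place of 3,5-dichlorophenyl on a sulfonyl sulfur. Among the measured compounds shown here, the only step recorded, a 7.7-fold higher number from compound 1 to compound 2 (0.89 log units; beyond the scatter), changes the other aryl group, not the group on the sulfonyl sulfur, so no measured step bears directly on this change. Compounds 1 and 2 carry the same sulfonyl aryl as compound 4 and span a wide gap between them, which limits confidence. A small step, a 1.3-fold lower number from compound 3 to compound 4 (0.10 log units; within the scatter), is expected, within the scatter. Compound 4 is estimated at 0.8 mL/min, range 0.3 mL/min to 2 mL/min.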

Compound 4, intrinsic clearance in a liver preparation (reported as CLH), per the amount of preparation that the assay uses: 0.19 mL/min
Compound 4: middle estimate off by 4.2-fold (0.62 log units), on the high side, outside the stated range (below it).
By their numbers in this assay, from the lowest: compounds 1 and 4 (each within the scatter of the next); then compounds 3 and 2 (each within the scatter of the next).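

In this assay, the group on the sulfonyl sulfur now has a step of its own: with 4-fluorophenyl kept on the aromatic carbon, 3-chloro-4-fluorophenyl in place of 3,5-dichlorophenyl gives a 5.3-fold lower number from compound 3 to compound 4 (0.73 log units; beyond the scatter) and so lies beyond the scatter. With 3-chloro-4-fluorophenyl kept on the sulfonyl sulfur, 4-fluorophenyl in place of 2-fluorophenyl gives a 7.3-fold lower number from compound 2 to compound 4 (0.86 log units; beyond the scatter) as a step beyond the scatter. 4-Fluorophenyl in place of 3-chlorophenyl gives a 1.1-fold higher number from compound 1 to compound 4 (0.02 log units; within the scatter) and stays within the scatter.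

Open, from the compounds shown here alone, is whether the sulfonyl step holds with 2-fluorophenyl or 3-chlorophenyl on the aromatic carbon, and how a sulfonyl aryl group carrying an amine would read. No evidence at hand gives a cause for these steps.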